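This account rests on a few compounds, and the source may have more. Where it says the series, first, only, none or still open, it means among the compounds named here.

Compound 1 `C=CCc1cc(C(C)=O)c(O)cc1OCCCCC#N` gives 92% in an assay on isolated protein for inhibition of leukotriene B4 receptor 1 (Homo sapiens), tested at 10 uM; on this read-out higher numbers stand for more inhibition at the one concentration tested (going by the name of the read-out) and lower numbers for less inhibition; compound 2 `C=CCc1cc(C(C)=O)c(O)cc1OCCCCCC#N` gives 81%; compound 3 `C=CCc1cc(C(C)=O)c(O)cc1OCCCCCCC#N` gives 97%.

Compound 3 stands highest of the three numbers. The steps that lead to it are a number 5 percentage points higher from compound 1 to compound 3 (within the scatter) and a number 16 percentage points higher from compound 2 to compound 3 (beyond the scatter), while a number 11 percentage points lower from compound 1 to compound 2 (beyond the scatter). Compound 4 `C=CCCCCOc1cc(O)c(C(C)=O)cc1CC=C` differs from compound 3 in one place: vinyl in place of 2-cyanoethyl on a saturated chain carbon, four bonds along the chain from an oxygen on an aromatic ring. The measured steps all keep the nitrile and vary only the chain between it and the aromatic oxygen, so none of them tests removal of the nitrile itself; they bear on the change only indirectly and were modest in size. A modest loss is therefore expected, a number 22 percentage points lower from compound 3 to compound 4 (beyond the scatter), and compound 4 is estimated at 75%, with a range from 50% to 95%.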

Compound 4, a percentage reported as inhibition, at one concentration (the size of the read-out at that concentration, not a potency): 73%
Estimate against measurement, compound 4: 2 percentage points above; the range from low to high includes it.
By their numbers in this assay, from the lowest: compounds 4 and 2 (each within the scatter of the next); then compounds 1 and 3 (each within the scatter of the next).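

With a vinyl in place of the nitrile-bearing 2-cyanoethyl on this saturated chain carbon, compound 4 still gives 73% in this assay, so inhibition at this concentration does not depend on the nitrile. Against the nitrile compounds, the result varies: there is a number 24 percentage points lower from compound 3 to compound 4 (beyond the scatter) and a number 19 percentage points lower from compound 1 to compound 4 (beyond the scatter), but a number 8 percentage points lower from compound 2 to compound 4 (within the scatter). Nothing measured here accounts for this difference.

From the compounds shown here alone, whether an amine or a carboxylic acid in this place would retain inhibition remains open, as does the effect of a longer chain ending in vinyl.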